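The source may hold more compounds than are shown below. What is called first, only, known or untested is meant among the compounds shown, and "the series" means these compounds.

Working notes on the series. Compound 1 `N#Cc1ccc(-n2cc(COc3cccc(NC(=O)Nc4ccc(Cl)c(C(F)(F)F)c4)c3)nn2)cc1` and compound 2 `O=C(Nc1cccc(OCc2cn(-c3ccc(I)cc3)nn2)c1)Nc1ccc(Cl)c(C(F)(F)F)c1` share one core and differ only in the group carried by the aromatic ring on the ring nitrogen. In a functional assay on HepG2 cells (Homo sapiens) for inhibition, read by MTT assay, with a stated time of 72 h (a higher number here means a weaker inhibitor, a lower number a stronger inhibitor), compound 1 gives 2980 nM, and compound 2 gives 2690 nM. Within the data shown here, the single measured step is a 1.1-fold lower number from compound 1 to compound 2 (0.04 log units; within the scatter). Compound 1 thus holds the higher of the two numbers recorded, but its gap to compound 2 lies within the scatter, so no order between the two can be read.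

Compound 3 `O=C(Nc1cccc(OCc2cn(-c3ccccc3C(F)(F)F)nn2)c1)Nc1ccc(Cl)c(C(F)(F)F)c1` is not yet measured. Its change from compound 1: 2-(trifluoromethyl)phenyl in place of 4-cyanophenyl on an aromatic nitrogen. The measured step from compound 1 to compound 2 bears on this only loosely: it exchanged one group for another on the same aromatic ring and moved the number within the scatter. Among the measured compounds shown here, compound 3 replaces the whole group, and no measured step covers such an exchange. The step expected in this assay is therefore estimated as small, a 1.0-fold higher number from compound 1 to compound 3 (0.00 log units; within the scatter), with no direction beyond the scatter. Compound 3 is expected to give 3000 nM, with a range from 1200 nM to 8000 nM.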

Compound 3, half-maximal inhibitory concentration: 2320 nM
Beside the measured number, compound 3's estimate is 1.3-fold (0.11 log units) above it; low and high end bracket the measured number.
By their numbers in this assay, from the lowest: compounds 3, 2 and 1 (each within the scatter of the next).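

In this assay, the exchange of 4-cyanophenyl for 2-(trifluoromethyl)phenyl on the aromatic nitrogen gives a 1.3-fold lower number from compound 1 to compound 3 (0.11 log units; within the scatter), and the exchange of 4-iodophenyl for the same group gives a 1.2-fold lower number from compound 2 to compound 3 (0.06 log units; within the scatter). The earlier step changed only the group named at the 4-position of the phenyl, whereas these two steps also bring a different substituent in the 2-position, and both still lie within the scatter. Across these three compounds, then, neither the kind of substituent nor its location on the phenyl separates the numbers, and no order among them can be read. No measurement at hand bears on the reason for this result.

From the compounds shown here alone, all three groups on this nitrogen are substituted phenyl groups, so it remains open whether a phenyl carrying an amine or a carboxylic acid, or a longer alkyl chain in place of the phenyl, would give a step beyond the scatter. The rest of the shared core is the same in all three compounds, so the compounds shown say nothing about how the number responds to a change there.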